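Changing the group on an aromatic nitrogen

The source may report more compounds than this note shows. Statements on the series, on what has been measured and on what is new or still open speak of the compounds shown alone.

In a functional assay on MCF7 cells (Homo sapiens) for cytotoxicity, read by MTT assay, with a stated time of 96 h (on this read-out lower numbers stand for stronger inhibition and higher numbers for weaker inhibition), the measured compounds read as follows:
Compound 1 `COc1cc(C(=O)c2cn(-c3ccccc3)cc2-c2ccc(N)cc2)cc(OC)c1OC` gives 9 nM
Compound 2 `COc1ccccc1-n1cc(C(=O)c2cc(OC)c(OC)c(OC)c2)c(-c2ccccc2)c1` gives 150 nM
Compound 3 `COc1cc(C(=O)c2cn(-c3cccc(Br)c3)cc2-c2ccccc2)cc(OC)c1OC` gives 78 nM

Compound 3 cannot be told apart from compound 2, while compound 1 lies lower, beyond the scatter. The next compound, compound 4 `COc1ccc(-n2cc(C(=O)c3cc(OC)c(OC)c(OC)c3)c(-c3ccccc3)c2)cc1`, carries 4-methoxyphenyl in place of 3-bromophenyl on an aromatic nitrogen and is otherwise unchanged. For the measured compounds named here, the only measured change at that nitrogen is a 1.9-fold lower number from compound 2 to compound 3 (0.28 log units; within the scatter) and it stayed within the scatter. No step beyond the scatter is therefore expected in this assay for this swap. The estimated step is a 1.3-fold higher number from compound 3 to compound 4 (0.11 log units; within the scatter) and no more. Compound 4 is expected at 100 nM with an estimated range from 35 nM to 300 nM in this measurement.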

Compound 4, half-maximal inhibitory concentration: 120 nM
Compound 4: the middle estimate sits 1.2-fold (0.08 log units) below what was measured, within the range that was stated.
By their numbers in this assay, from the lowest: compound 1; then compounds 3, 4 and 2 (each within the scatter of the next).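

In this assay, a third group on the aromatic nitrogen again stays within the scatter, with a 1.5-fold higher number from compound 3 to compound 4 (0.19 log units; within the scatter). The methoxy group can also stand as 2-methoxyphenyl or 4-methoxyphenyl without a step beyond the scatter, with a 1.3-fold lower number from compound 2 to compound 4 (0.10 log units; within the scatter), so compound 2, compound 3 and compound 4 cannot be told apart. Nothing available explains why these groups read alike.

Still open, going by these compounds, is whether an amine or a carboxylic acid on this phenyl ring would keep the number in the same range. On these data alone, a longer chain on the nitrogen in place of the ring is equally open.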